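Two Chlorines on the Benzyl Ring of Compound 4

The compounds below may be only part of what the source reports. "The series", "measured", "known", "first", "only" and "open" are said of these compounds alone.

Three compounds share one core and differ only in the ring hanging from a saturated chain carbon. Compound 1 `Cc1ccc(S(=O)(=O)N(Cc2nnc(Cc3ccccc3F)o2)c2cccc(Cl)c2C)cc1` gives 501 nM in an assay on CHO cells for displacement of a labelled ligand from prostaglandin E2 receptor EP1 subtype (Homo sapiens); a lower number here means a stronger inhibitor, a higher number a weaker inhibitor. Compound 2 `Cc1ccc(S(=O)(=O)N(Cc2nnc(Cc3cccc(F)c3)o2)c2cccc(Cl)c2C)cc1` gives 316 nM, and compound 3 `Cc1ccc(S(=O)(=O)N(Cc2nnc(Cc3cccc(Cl)c3)o2)c2cccc(Cl)c2C)cc1` gives 158 nM, the lowest of the three numbers. The measured steps are a 1.6-fold lower number from compound 1 to compound 2 (0.20 log units; within the scatter), a 2.0-fold lower number from compound 2 to compound 3 (0.30 log units; within the scatter) and a 3.2-fold lower number from compound 1 to compound 3 (0.50 log units; beyond the scatter). Compound 4 `Cc1ccc(S(=O)(=O)N(Cc2nnc(Cc3c(Cl)cccc3Cl)o2)c2cccc(Cl)c2C)cc1` carries 2,6-dichlorophenyl in place of 3-chlorophenyl on a saturated chain carbon bound to an aromatic carbon. Among the compounds with values here, only one step is beyond the scatter, a 3.2-fold lower number from compound 1 to compound 3 (0.50 log units; beyond the scatter), and it moved the number down; the new change goes partly back toward the pattern of compound 1 while adding a second chlorine, so no firm direction follows. The value of compound 4 is therefore estimated at 320 nM, between 100 nM and 1000 nM. The expected step is a 2.0-fold higher number from compound 3 to compound 4 (0.31 log units; beyond the scatter).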

Compound 4, half-maximal inhibitory concentration: 63.1 nM
Beside the measured number, compound 4's estimate is 5.1-fold (0.71 log units) above it; the whole stated range lies above it.
By their numbers in this assay, from the lowest: compound 4; then compounds 3, 2 and 1 (each within the scatter of the next, the first and the last beyond it).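

Putting 2,6-dichlorophenyl in place of 3-chlorophenyl on this saturated chain carbon gives a 2.5-fold lower number from compound 3 to compound 4 (0.40 log units; beyond the scatter), so this position accepts a ring carrying two chlorines, and the number falls further. The same ring gives a 5.0-fold lower number from compound 2 to compound 4 (0.70 log units; beyond the scatter) and a 7.9-fold lower number from compound 1 to compound 4 (0.90 log units; beyond the scatter), which makes compound 4 the strongest inhibitor of the four, with every step to it beyond the scatter. Nothing measured here explains this drop. Still open, from the compounds shown here alone, is whether both chlorines are needed, and whether 2,6-difluorophenyl or a ring carrying an amine would give a similar number.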